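A few compounds are considered here, and "the series" means these few. Any claim that something is new, unique, unknown or untested is made for them only; others in the source may bear on it.

Measured so far:
Compound 1 `O=S1(=O)C=Cc2cccc(Nc3cccc(F)c3)c21` - 1220 nM
Compound 2 `COc1ccccc1Nc1cccc2c1S(=O)(=O)C=C2` - 5000 nM

In a functional assay on HCT-116 cells (Homo sapiens) for antiproliferative activity, read by MTT assay, with a stated time of 72 h (a higher number here means a weaker inhibitor, a lower number a stronger inhibitor), compound 2 has the higher of the two numbers, at 5000 nM and so is the weaker inhibitor, while compound 1 gives 1220 nM and the gap between them lies beyond the usual scatter.

Compound 3 `O=S1(=O)C=Cc2cccc(Nc3ccccc3C(F)(F)F)c21` has not been measured yet. It keeps the core of compound 2 and carries trifluoromethyl in place of methoxy on an aromatic carbon. Among the compounds with values here, no measured pair shows this swap, so the guidance is thin. A slight lean toward a lower number rests on compound 1 alone, whose 1220 nM shows that this core can give a lower number than compound 2 does. In this assay the expected change is small and probably within the scatter, an estimated 1.7-fold lower number from compound 2 to compound 3 (0.22 log units; within the scatter) as the likely move. The estimated value for compound 3 is 3000 nM with an expected range from 1000 nM to 9000 nM as the likely span.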

Compound 3, half-maximal inhibitory concentration: 5950 nM
Compound 3: middle estimate off by 2.0-fold (0.30 log units), on the low side; the range from low to high includes it.
By their numbers in this assay, from the lowest: compound 1; then compounds 2 and 3 (each within the scatter of the next).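

Within this assay putting trifluoromethyl in place of methoxy on this aromatic carbon, ortho to a large group, gives a 1.2-fold higher number from compound 2 to compound 3 (0.08 log units; within the scatter) and so provides the first direct reading of a change at this place. The two groups differ in their counts of heavy atoms and hydrogen-bond acceptors, yet this assay does not separate them on this core. No separate measurement bears on this result.

The compounds shown leave open whether a different group at this place, such as an amine, a carboxylic acid or a longer chain, would move the number beyond the scatter. They also leave open whether the same swap would give so small a step on another carbon of this aromatic ring.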